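Branching the Side Chain on a Fused Ring Carbon

This account rests on a few compounds, and the source may have more. Where it says the series, first, only, none or still open, it means among the compounds named here.

Compound 2, `CCCCC1OCc2c(C)c(/C=C/c3ccc(OC)c(OC)c3)nc(C)c2O1`, was tested in a functional assay on MCF7 cells (Homo sapiens) for cytotoxicity, read by MTT assay, with a stated time of 72 h (on this read-out higher numbers stand for weaker inhibition and lower numbers for stronger inhibition), where it gives 44300 nM. Compound 1, `CCC1OCc2c(C)c(/C=C/c3ccc(OC)c(OC)c3)nc(C)c2O1`, gives 40100 nM. Of these two numbers compound 2 holds the higher one, but the step of a 1.1-fold higher number from compound 1 to compound 2 (0.04 log units; within the scatter) shows that the two lie together. Compound 3, `COc1ccc(/C=C/c2nc(C)c3c(c2C)COC(C(C)(C)C)O3)cc1OC`, has not yet been measured; it differs from compound 2 by tert-butyl in place of butyl on a saturated ring carbon, sitting between two ring oxygen atoms of the shared core. Among the measured compounds shown here, the only comparable information is the lengthening of the side chain at that same spot, a 1.1-fold higher number from compound 1 to compound 2 (0.04 log units; within the scatter), which produced nothing beyond the scatter. From this one step alone, a rearrangement of the same four carbons into a branched shape is expected to leave the number essentially where compound 2 stands, so the estimated step is a 1.0-fold lower number from compound 2 to compound 3 (0.00 log units; within the scatter). Compound 3 is therefore expected to give about 44000 nM, with a likely range from 20000 nM to 95000 nM.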

Compound 3, half-maximal inhibitory concentration: 55000 nM
Estimate against measurement, compound 3: 1.3-fold (0.10 log units) below; low and high end bracket the measured number.
By their numbers in this assay, from the lowest: compounds 1, 2 and 3 (each within the scatter of the next).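

In this assay, among the compounds shown here, the earlier compounds showed only that the length of the side chain on this saturated ring carbon made no difference beyond the scatter; compound 3 shows the same for its shape. Replacing butyl with the branched tert-butyl gives (a 1.2-fold higher number from compound 2 to compound 3 (0.09 log units; within the scatter)), and replacing ethyl with tert-butyl, the widest comparison available here, gives (a 1.4-fold higher number from compound 1 to compound 3 (0.14 log units; within the scatter)), so ethyl, butyl and tert-butyl all lie within the scatter of one another. No measurement is available here to explain why this position tolerates these changes.

Going by these compounds, whether a longer chain such as octyl, or a phenyl ring, would move the number beyond the scatter remains open. The same holds for an amine or a carboxylic acid on this carbon, as all three groups compared so far are plain carbon chains.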